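The source may report more compounds than this note shows. Statements on the series, on what has been measured and on what is new or still open speak of the compounds shown alone.

Compound 1 `O=C(Nc1ccc(F)cc1)c1cc(Cl)ccc1O` gives 1.6 ug/mL in a physicochemical assay for solubility; on this read-out lower numbers stand for lower solubility and higher numbers for higher solubility. Compound 2 `O=C(Nc1ccc(Cl)cc1)c1cc(Cl)ccc1O` reaches only a limit of this assay, < 1 ug/mL. Compound 3 `O=C(Nc1ccc(C(F)(F)F)c(Cl)c1)c1cc(Br)ccc1O` likewise returns a limit, < 1 ug/mL. For the measured compounds named here, the one change made between the two measured analogues, (fluoro in place of chloro on an aromatic carbon), gave an at least 1.6-fold higher number from compound 2 to compound 1 (0.20 log units; that floor lies within the scatter). The difference between the cores of compound 2 and compound 3 is not broken down here. Compound 4 `O=C(Nc1ccc(C(F)(F)F)c(F)c1)c1cc(Br)ccc1O` carries the same kind of change on the core of compound 3, (fluoro in place of chloro on an aromatic carbon), though the place differs: ortho to a trifluoromethyl group and meta to a large group rather than para to a large group. Given that the limit of < 1 ug/mL in this assay, at which 2 of the 3 values shown sit, makes the starting point of compound 3 uncertain, the step from compound 3 to compound 4 in this assay is expected to be about a number no lower from compound 3 to compound 4 (the limit leaves the size open). Compound 4 is accordingly estimated at 1 ug/mL, between 0.3 ug/mL and 3 ug/mL.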

Compound 4, solubility: < 1 ug/mL
Compound 4 ended at the assay's limit; the forecaster's own chance of this, stated with the estimate: 50%; the middle value sits exactly at the limit.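

Compound 3 and compound 4 both end at a limit in this assay, so no step can be read between them: the limit of < 1 ug/mL in this assay, at which 3 of the 4 values shown sit.

On these data alone, whether fluoro in place of chloro shifts the read-out on the core of compound 3 stays open.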